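From Methyl to Nitro on the Shared Core

The compounds below may be only part of what the source reports. "The series", "measured", "known", "first", "only" and "open" are said of these compounds alone.

In a functional assay on HCT-116 cells (Homo sapiens) for cytotoxicity, read by MTT assay, with a stated time of 72 h (on this read-out higher numbers stand for weaker inhibition and lower numbers for stronger inhibition), compound 1 (`O=C(NCCCn1ccnc1)c1cc2ccccc2s1`) gives 25000 nM as a measured number. Compound 2 (`Cc1ccc(C(=O)NCCCn2ccnc2)s1`) stands only at a limit, > 320000 nM in this assay and not a number. The next compound, compound 3 (`O=C(NCCCn1ccnc1)c1ccc([N+](=O)[O-])s1`), has nitro in place of methyl on an aromatic carbon, next to the ring sulfur (nitro in place of methyl on an aromatic carbon). Among the compounds with values here, no step between measured compounds is available as a guide. Within the data shown here, a shift toward stronger inhibition is expected in this assay and only a moderate one, since compound 1 at 25000 nM is the sole measured number to go by. The expected change is put at an at least 2.6-fold lower number from compound 2 to compound 3 (0.42 log units; beyond the scatter) by this rough reckoning. For compound 3 the estimate is 120000 nM as a middle value, with an expected range from 25000 nM to 320000 nM in all.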

Compound 3, half-maximal inhibitory concentration: > 390000 nM
Compound 3: a limit, no number (the forecaster's own chance of this, stated with the estimate: 35%); at least 3.2-fold (0.51 log units) between middle value and limit.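

No step can be read between compound 2 and compound 3, since each stands only at a limit in this assay and neither gives a number. The compounds shown leave open how nitro and methyl compare in that position on the shared core.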